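This account rests on a few compounds, and the source may have more. Where it says the series, first, only, none or still open, it means among the compounds named here.

Within the data shown here, in a functional assay on HeLa cells (Homo sapiens) for antiproliferative activity (a lower number here means a stronger inhibitor, a higher number a weaker inhibitor), compound 2 (`CCOC(=O)CSC(=O)[C@](C)(O)[C@@]12CC/C(C)=C/[C@@H](O)C(=O)/C=C/C=C/c3csc(n3)[C@@H](C)N(C(=O)C1)[S+]2[O-]`) gives 1300 nM as the higher of the two numbers so far, while compound 1 (`C/C1=C\[C@@H](O[C@@H]2CCCCO2)C(=O)/C=C/C=C/c2csc(n2)[C@@H](C)N2C(=O)C[C@@]([C@@](C)(O)C(=O)SCc3oc(=O)oc3C)(CC1)[S+]2[O-]`) gives 0.67 nM at the low end, a gap far beyond the scatter. Compound 3 (`C/C1=C\[C@@H](O)C(=O)/C=C/C=C/c2csc(n2)[C@@H](C)N2C(=O)C[C@@]([C@@](C)(O)C(=O)SCc3oc(=O)oc3C)(CC1)[S+]2[O-]`) differs from compound 2 on a saturated chain carbon bound to a sulfur (a group of 7 heavy atoms (4 carbon, 3 oxygen; one five-membered aromatic ring with 2 hetero atoms) in place of a group of 5 heavy atoms (3 carbon, 2 oxygen; no ring), on a saturated chain carbon bound to a sulfur). The entering group has a five-membered aromatic ring with 2 hetero atoms. Compound 1 carries that same group and gives 0.67 nM in this assay as a much stronger inhibitor. The expected step is therefore a large fall in the number (a 260-fold lower number from compound 2 to compound 3 (2.41 log units; beyond the scatter)) and lies beyond the scatter. The estimated value for compound 3 is 5 nM (range 0.5 nM to 100 nM).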

Compound 3, half-maximal inhibitory concentration: 4.6 nM
Compound 3: the middle estimate sits 1.1-fold (0.04 log units) above what was measured; the measured number falls inside the stated range.
By their numbers in this assay, from the lowest: compound 1; then compound 3; then compound 2.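

In this assay, the step of a 280-fold lower number from compound 2 to compound 3 (2.45 log units; beyond the scatter) isolates the group on a saturated chain carbon bound to a sulfur, which compounds 1 and 2 could not do because they differ in two places. The step of a 6.9-fold higher number from compound 1 to compound 3 (0.84 log units; beyond the scatter) shows that replacing oxan-2-yl with hydrogen on an oxygen on a saturated carbon has a smaller effect, though one still beyond the scatter. No available evidence explains either step. From the compounds shown here alone, whether a benzyl group or a carboxylic acid at that carbon would match the entering group remains open, as does whether an acetyl group on that oxygen would match oxan-2-yl.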